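The compounds below may be only part of what the source reports. "The series", "measured", "known", "first", "only" and "open" are said of these compounds alone.

Measured so far:
- compound 1 `CC(=O)Nc1ccc(O)c(C(=O)OCCn2c([N+](=O)[O-])cnc2C)c1`: 15.5%
- compound 2 `CC(=O)Nc1ccc(O)c(C(=O)O)c1`: 0%
- compound 3 `Cc1ncc([N+](=O)[O-])n1CCOC(=O)c1cc(NC(=O)[C@H](C)NC(=O)OCc2ccccc2)ccc1O`: 36.1%

In a functional assay on the whole organism (strain Wistar) for inhibition, with Rattus norvegicus as the target, read by paw edema, with stated times of 1 h and 4 h, at a dose of 10 mg/kg by the intraperitoneal route (on this read-out lower numbers stand for less inhibition and higher numbers for more inhibition at the one dose given (going by the name of the read-out)), compound 3 stands highest of the three numbers. Its nearest neighbour is compound 1 at 15.5%, a gap beyond the scatter, and furthest away lies compound 2 at 0%, also beyond the scatter. The next compound, compound 4 `Cc1ncc([N+](=O)[O-])n1CCOC(=O)c1cc(NC(=O)CNC(=O)OCc2ccccc2)ccc1O`, differs from compound 3 in one place: hydrogen in place of methyl on a saturated chain carbon bound to an amide-type nitrogen and a carbonyl carbon. For the measured compounds named here, no pair of measured compounds shows this change, so its effect is unknown here. A small step in this assay is expected, not beyond the scatter, in either direction. For compound 4 the expected reading is 32%, between 15% and 48%. The step of a number 4.1 percentage points lower from compound 3 to compound 4 (within the scatter) is thus estimated to be small.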

Compound 4, a percentage reported as inhibition, in the whole organism at one dose (the size of the read-out at that dose, not a potency): 52.8%
Estimate against measurement, compound 4: 20.8 percentage points below, and the stated range ends below it.
By their numbers in this assay, from the lowest: compound 2; then compound 1; then compound 3; then compound 4.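

In this assay, for the compounds shown here, the reading is a number 16.7 percentage points higher from compound 3 to compound 4 (beyond the scatter), so this saturated chain carbon responds to losing a single methyl, something no earlier pair could show. The step of a number 37.3 percentage points higher from compound 1 to compound 4 (beyond the scatter) adds that (benzyloxycarbonyl)amino in place of hydrogen on a saturated chain carbon bound to a carbonyl carbon goes with a large rise. Nothing available gives a reason for either step.

Still open, from the compounds shown here alone, is how an ethyl group or a longer chain at this carbon would read. Also open, going by these compounds, is how a free amine would read in place of the (benzyloxycarbonyl)amino group.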